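The source may hold more compounds than are shown below. What is called first, only, known or untested is meant among the compounds shown, and "the series" means these compounds.

Values so far in an ADME assay on MT4 cells (Homo sapiens) for cytotoxicity; on this read-out lower numbers stand for higher toxicity in this test and higher numbers for lower toxicity in this test
- compound 1 `CC[C@H]1CC[C@H](c2ccc(NC(=S)Nc3cccc(C(F)(F)F)c3)cc2)CC1` gives 39000 nM
- compound 2 `CCCC[C@H]1CC[C@H](c2ccc(NC(=S)Nc3cccc(C(F)(F)F)c3)cc2)CC1` gives 22000 nM
- compound 3 `Fc1ccc(NC(=S)Nc2cccc(C(F)(F)F)c2)cc1` gives 31000 nM
- compound 4 `Fc1cccc(NC(=S)Nc2cccc(C(F)(F)F)c2)c1` is not yet measured

Compound 3, at 31000 nM, cannot be separated from the other two compounds: a 1.3-fold lower number from compound 1 to compound 3 (0.10 log units; within the scatter) and a 1.4-fold higher number from compound 2 to compound 3 (0.15 log units; within the scatter) are both within the scatter. The change under study is 3-fluorophenyl in place of 4-fluorophenyl on an amide-type nitrogen. Going by the values given here, no measured pair shows this exact change. The closest evidence comes from those two replacements of a whole group, which, like a 1.8-fold lower number from compound 1 to compound 2 (0.25 log units; within the scatter), stay within the scatter. No shift beyond the scatter is therefore expected in this assay. The expected change is a 1.0-fold lower number from compound 3 to compound 4 (0.01 log units; within the scatter), with no firm direction. For compound 4 the estimated value is 30000 nM, with an expected range from 15000 nM to 60000 nM.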

Compound 4, half-maximal cytotoxic concentration: 20000 nM
The estimate for compound 4 lay 1.5-fold (0.18 log units) above the measured number, and the stated range covers the measured number.
By their numbers in this assay, from the lowest: compounds 4, 2, 3 and 1 (each within the scatter of the next).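

In this assay, going by these compounds alone, the exchange of 4-fluorophenyl for 3-fluorophenyl gives a 1.6-fold lower number from compound 3 to compound 4 (0.19 log units; within the scatter) as the first direct reading of this change on the amide-type nitrogen. On these values, the two fluorophenyl groups cannot be separated at this place, and all four compounds remain within the scatter of their neighbours in the ranking. No measurement at hand bears on the origin of this step.

Still open, from the compounds shown here alone, is whether an amine or a carboxylic acid on this phenyl ring would move the number beyond the scatter. A longer chain on the cyclohexyl ring is equally unresolved.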